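The source may report more compounds than this note shows. Statements on the series, on what has been measured and on what is new or still open speak of the compounds shown alone.

Compound 1, with structure `O=C1/C(=C\c2ccc(O)cc2)c2ccccc2N1c1c(Cl)cccc1Cl`, has no result in a functional assay on MOLT-4 cells (Homo sapiens) for cytotoxicity, read by MTT assay, with a stated time of 72 h; a higher number here means that more compound is needed for the effect, a lower number that less compound is needed; for compound 1 the record reads "not determined" (no result reported). Compound 2, with structure `Cc1ccc2nc(Cl)c(/C=C3\C(=O)N(c4c(Cl)cccc4Cl)c4ccccc43)cc2c1C`, stands the same way, its entry being "not determined" (no result reported). Going by the values given here, the only number comes from compound 3, structure `O=C1/C(=C\c2cccc(Oc3ccccc3)c2)c2ccccc2N1c1c(Cl)cccc1Cl`, which in this assay gives 6 ug/mL. Compound 4, structure `O=C1/C(=C\c2ccccc2Cl)c2ccccc2N1c1c(Cl)cccc1Cl`, differs from compound 1 by 2-chlorophenyl in place of 4-hydroxyphenyl on a double-bonded chain carbon bound to a double-bonded ring carbon. Compound 1 has no number. The size and direction of the step from compound 1 to compound 4 in this assay therefore cannot be judged from the data, and no step beyond the usual scatter is assumed. Compound 4 is expected to land near compound 3, estimated at 6 ug/mL with a range from 2 ug/mL to 20 ug/mL.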

Compound 4, concentration for half-maximal effect: 7 ug/mL
Compound 4: middle estimate off by 1.2-fold (0.07 log units), on the low side; the measured number falls inside the stated range.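

No step can be read between compound 1 and compound 4, and no data at hand explain the result for compound 4. The compounds shown leave open what replacing 4-hydroxyphenyl with 2-chlorophenyl does in this assay.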